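Sec-butyl in place of 2-methoxyethyl on compound 3

The source may hold more compounds than are shown below. What is called first, only, known or untested is meant among the compounds shown, and "the series" means these compounds.

Measured in an ADME assay on RAW264.7 cells (Mus musculus) for cytotoxicity, read by MTT assay, with a stated time of 24 h; a higher number here means that more compound is tolerated, a lower number that less compound is tolerated:
compound 1 `CC/C=C\C[C@H]1C(=O)C=C[C@H]1CC(=O)OCCC`: 35 uM
compound 2 `CC/C=C\C[C@H]1C(=O)C=C[C@H]1CC(=O)OCCCCC`: 37 uM
compound 3 `CC/C=C\C[C@H]1C(=O)C=C[C@H]1CC(=O)OCCOC`: 160 uM

Compound 3 stands highest of these three, and its gaps to both others lie beyond the scatter. The unmeasured compound 4 `CC/C=C\C[C@H]1C(=O)C=C[C@H]1CC(=O)OC(C)CC` carries sec-butyl in place of 2-methoxyethyl on an oxygen next to a carbonyl group. Among the measured compounds shown here, two measured steps bear most directly on this change: a 4.6-fold higher number from compound 1 to compound 3 (0.66 log units; beyond the scatter) and a 4.3-fold higher number from compound 2 to compound 3 (0.64 log units; beyond the scatter). Both are modest and both replace a methoxy-free chain with the methoxy one. The step of a 1.1-fold higher number from compound 1 to compound 2 (0.02 log units; within the scatter) lies within the scatter. Compound 4 lacks methoxy, so a modest step to a lower number is expected in this assay. The expected step is a 4.4-fold lower number from compound 3 to compound 4 (0.65 log units; beyond the scatter). Compound 4 is estimated at 36 uM, with an expected range of 18 uM to 70 uM.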

Compound 4, half-maximal toxic concentration: 53 uM
For compound 4 the middle estimate is 1.5-fold (0.17 log units) below the measured one; the range from low to high includes it.
By their numbers in this assay, from the lowest: compounds 1, 2 and 4 (each within the scatter of the next); then compound 3.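

In this assay, sec-butyl places compound 4 with the compounds that lack methoxy: it stands clearly apart from the 2-methoxyethyl compound (a 3.0-fold lower number from compound 3 to compound 4 (0.48 log units; beyond the scatter)), but not from the pentyl compound (a 1.4-fold higher number from compound 2 to compound 4 (0.16 log units; within the scatter)) or the propyl compound (a 1.5-fold higher number from compound 1 to compound 4 (0.18 log units; within the scatter)). Among these four compounds, a branched chain on an oxygen next to a carbonyl group therefore gives no separation from the straight chains without methoxy, and only 2-methoxyethyl stands apart. No evidence is available to explain this difference. The compounds shown leave open whether a longer chain ending in methoxy, or a chain carrying an amine or a carboxylic acid, would stand with compound 3 or with the others.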